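Isobutyl for isopropyl on the ketone of compound 2

The source may report more compounds than this note shows. Statements on the series, on what has been measured and on what is new or still open speak of the compounds shown alone.

Measured compounds:
compound 1 `Cc1cc(C(=O)O)ccc1OCCCCOc1ccc(C(=O)CC(C)C)c(O)c1C` gives 192 nM
compound 2 `Cc1c(OCCCCOc2ccc(F)c(C(=O)O)c2)ccc(C(=O)C(C)C)c1O` gives 171 nM

Both values come from an assay on HEK293 cells for positive allosteric modulation of metabotropic glutamate receptor 2 (Rattus norvegicus), read by thallium flux, with a stated time of 2.5 min; on this read-out higher numbers stand for an effect only at larger amounts of compound and lower numbers for an effect already at smaller amounts. Within the data shown here, compound 2 holds the lowest of the two numbers so far, and its nearest neighbour is compound 1, whose number is a little higher but within the scatter, so the two compounds cannot be told apart on this read-out. Compound 3 `Cc1c(OCCCCOc2ccc(F)c(C(=O)O)c2)ccc(C(=O)CC(C)C)c1O` is not yet measured. It differs from compound 2 in one place: isobutyl in place of isopropyl on a carbonyl carbon. Among the measured compounds shown here, no step between two measured compounds covers this change, and compound 1 carries the same isobutylcarbonyl group on a differently built core, so its value offers only a loose comparison. Against that background, the author expects no step beyond the scatter from compound 2 to compound 3, with an estimated change of a 1.1-fold higher number from compound 2 to compound 3 (0.02 log units; within the scatter). Compound 3 is therefore expected to give about 180 nM in this assay, estimated between 90 nM and 360 nM.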

Compound 3, half-maximal effective concentration: 153 nM
Beside the measured number, compound 3's estimate is 1.2-fold (0.07 log units) above it; the measured number falls inside the stated range.
By their numbers in this assay, from the lowest: compounds 3, 2 and 1 (each within the scatter of the next).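

In this assay, among these compounds, isobutyl in place of isopropyl on the carbonyl carbon gives a 1.1-fold lower number from compound 2 to compound 3 (0.05 log units; within the scatter) and so adds a first direct reading for this position: the change of chain there does not move the number beyond the scatter. Among the compounds shown here, with the isobutylcarbonyl group held the same, 3-carboxy-4-fluorophenyl in place of 4-carboxy-2-methylphenyl on the oxygen gives a 1.3-fold lower number from compound 1 to compound 3 (0.10 log units; within the scatter) and thus also stays within the scatter, a change at the other end of the molecule that no earlier step covered. No data are available that explain either result. As far as these compounds go, whether a longer chain or an amine on the carbonyl carbon would also stay within the scatter of compound 2 remains open. So does the outcome of chlorine in place of the fluorine in the 3-carboxy-4-fluorophenyl group.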